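Shortening the alkyne chain: what tolerance to expect

A few compounds are considered here, and "the series" means these few. Any claim that something is new, unique, unknown or untested is made for them only; others in the source may bear on it.

Measured compounds:
compound 1, `CCCCCCCCCCc1cc2cn(COCCO)c(O)nc-2n1`, gives 80000 nM
compound 2, `CCCCCCCC#Cc1cc2cn(COCCO)c(=O)nc2o1`, gives 200000 nM

Both numbers come from a functional assay on HEL cells (Homo sapiens), read by microscopy; a lower number here means that less compound is tolerated, a higher number that more compound is tolerated. Compound 2 stands highest of the two: compound 1 lies at a lower number, and the gap between them is beyond the usual scatter of repeated measurements. The two compounds differ in more than one place, so nothing more is drawn from that pair than what the two values show.

Compound 3, `CCCCC#Cc1cc2cn(COCCO)c(=O)nc2o1`, is the next compound to be measured in this assay . It differs from compound 2 in one place only: hydrogen in place of propyl on a saturated chain carbon, four bonds along the chain from a triple-bonded carbon. Among the measured compounds shown here, no step between measured compounds is available to guide this change, so the expectation rests on the structural change alone. Removing carbon from the chain is expected to leave the core unchanged and to make the compound somewhat more tolerated, so a modest step upward, a 1.5-fold higher number from compound 2 to compound 3 (0.18 log units; within the scatter), is expected, though it may well fall within the scatter. Compound 3 is therefore estimated at 300000 nM, with a range from 150000 nM to 800000 nM, and the assay may report only a limit.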

Compound 3, minimum cytotoxic concentration: > 100000 nM
Compound 3: no number, only a limit; the forecaster's own chance of this, stated with the estimate: 30%; the middle value lies beyond the limit too.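

Among the compounds shown here, no step from compound 2 to compound 3 can be read, because compound 3 carries only a limit and not a number: the limit of > 100000 nM in this assay, at which 1 of the 3 values shown sits. The compounds shown leave open whether hydrogen in place of propyl on this chain changes how much compound the cells tolerate, and by how much.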